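A few compounds are considered here, and "the series" means these few. Any claim that something is new, unique, unknown or untested is made for them only; others in the source may bear on it.

Working notes on the series. Among the measured compounds shown here, compound 1, `FC(F)=C(F)CCSc1nc2ccccc2[nH]1`, and compound 2, `O=S(=O)(CCC(F)=C(F)F)c1nc2ccc(OC(F)F)cc2[nH]1`, are the two measured members; compound 3, `O=S(=O)(CCC(F)=C(F)F)c1nc2ccccc2[nH]1`, has not yet been measured. In a functional assay on SH-SY5Y cells (Homo sapiens) for cytotoxicity, read by MTT assay, with a stated time of 48 h (a higher number here means a weaker inhibitor, a lower number a stronger inhibitor), compound 1 returns only a limit, > 120000 nM. In this assay compound 2 likewise returns only a limit, > 120000 nM. For the measured compounds named here, compound 2 thus stands at the limit of > 120000 nM in this assay, at which 2 of the 2 values shown sit, and no step between two measured numbers exists in this set. The change from compound 2 to compound 3 is hydrogen in place of difluoromethoxy on an aromatic carbon. With both measured values sitting at the same limit, nothing in the series points either way, and the step expected from compound 2 to compound 3 in this assay is a step that the limit leaves unreadable from compound 2 to compound 3, none beyond the scatter. The more likely outcome for compound 3 in this assay is again a limit rather than a number. Should a number come out, compound 3 is expected near 150000 nM in this assay, with a range from 60000 nM to 400000 nM.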

Compound 3, half-maximal inhibitory concentration: > 120000 nM
Compound 3: a limit, no number; the forecaster's own chance of this, stated with the estimate: 85%; the middle value is on the limit's open side.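

Among the compounds shown here, compound 3, like compound 2, returns only a limit in this assay, so no step between the two can be read. All three compounds sit at the same limit: the limit of > 120000 nM in this assay, at which 3 of the 3 values shown sit.

The compounds shown leave open whether replacing difluoromethoxy with hydrogen changes the half-maximal inhibitory concentration at all, and whether any compound in the series reaches a measurable value in this assay.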